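What one hydroxy group might do to compound 1

This account rests on a few compounds, and the source may have more. Where it says the series, first, only, none or still open, it means among the compounds named here.

Measured so far in a functional assay on Gurav cells (Homo sapiens) for inhibition, read by sulforhodamine B assay; a higher number here means a weaker inhibitor of growth, a lower number a stronger inhibitor of growth:
- compound 1 `c1ccc(-c2ccc(-c3ccc(-c4nc5ccccc5[nH]4)cc3)cc2)cc1`: 100000 nM
- compound 2 `FC(F)(F)Oc1ccc(-c2ccc(-c3ccc(-c4nc5ccccc5[nH]4)cc3)cc2)cc1`: 100000 nM

Compound 1 stands level with compound 2 at the digits shown, so this small set offers no better or worse neighbour to compare it with. Among the compounds with values here, only one step has been measured, no change at the digits printed from compound 1 to compound 2 (within the scatter), where trifluoromethoxy replaces hydrogen on an aromatic carbon.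

Compound 3 `Oc1cccc2[nH]c(-c3ccc(-c4ccc(-c5ccccc5)cc4)cc3)nc12` is compound 1 with a single change (hydroxy in place of hydrogen on an aromatic carbon). Here hydroxy takes the place of hydrogen on an aromatic carbon of a six-membered aromatic ring of carbon only, part of a fused system of two rings.

The measured step involves a different group, so it is only a loose guide. It does show a change that left the number in place, so no step beyond the scatter is expected in this assay. With one precedent, a move towards stronger growth inhibition remains possible, and the range is wider on that side.

The expected size of the change is a 1.4-fold lower number from compound 1 to compound 3 (0.15 log units; within the scatter). The estimate for compound 3 is 70000 nM, within an expected range of 15000 nM to 120000 nM.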

Compound 3, concentration for 50% growth inhibition: 1110 nM
Beside the measured number, compound 3's estimate is 63-fold (1.80 log units) above it; the measured number lies below the stated range.
By their numbers in this assay, from the lowest: compound 3; then compounds 1 and 2 (each within the scatter of the next).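

In this assay, adding a hydroxy group, 1 heavy atom, on an aromatic carbon of the six-membered ring of carbon only gives a 90-fold lower number from compound 1 to compound 3 (1.95 log units; beyond the scatter). Compounds 1 and 2 alone gave no sign that the number could be moved within this series, whereas compound 3 shows that a very small change to the core of compound 1 can turn a weak reading into a much stronger one, so this position matters greatly for growth inhibition in these cells. Nothing in the available information explains why this change has so large an effect.

The compounds shown cannot tell whether the gain belongs to the hydroxy group specifically or whether other small groups on the same carbon would serve as well. A methoxy group or an amine at this carbon would help separate those two readings, and a hydroxy group on another carbon of the same ring would show how closely the gain depends on this exact place.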